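A few compounds are considered here, and "the series" means these few. Any claim that something is new, unique, unknown or untested is made for them only; others in the source may bear on it.

Compound 1 `Cc1cc(C)cc(NC(=O)COc2cc(C)nc3ccc(OCc4ccccc4)cc23)c1`: in a physicochemical assay for solubility, in phosphate buffer, measured as kinetic solubility, with a stated time of 1 h, at pH 7.4 (a lower number here means a less soluble compound, a higher number a more soluble compound), compound 1 gives < 1000 nM, which is a limit of the assay and not a number.
Compound 2 `COc1ccc2nc(C)cc(OCC(=O)Nc3c(C)cccc3C)c2c1`: in this assay compound 2 gives 112000 nM.

Compound 2 therefore holds the only number shown in this assay; the other value is the limit of < 1000 nM in this assay, at which 1 of the 2 values shown sits. Going by the values given here, no two measured compounds differ from each other in one place, so no measured step can be drawn on.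

Compound 3 `COc1ccc2nc(C)cc(OCC(=O)Nc3ccc(Cl)cc3Cl)c2c1` differs from compound 2 by 2,4-dichlorophenyl in place of 2,6-dimethylphenyl on an amide-type nitrogen. Among the compounds with values here, with no measured step of this kind available, the size of the change has to be guessed; a move beyond the scatter, toward lower solubility, is expected rather than none at all. Compound 3 is estimated at 30000 nM, with a range from 5000 nM to 150000 nM. This amounts to an expected step of a 3.7-fold lower number from compound 2 to compound 3 (0.57 log units; beyond the scatter).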

Compound 3, solubility: 20500 nM
The estimate for compound 3 lay 1.5-fold (0.17 log units) above the measured number; the range from low to high includes it.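

In this assay, the place on an amide-type nitrogen responds to the change from 2,6-dimethylphenyl to 2,4-dichlorophenyl with a 5.5-fold lower number from compound 2 to compound 3 (0.74 log units; beyond the scatter), a step beyond the scatter. Both groups are six-membered aromatic rings of carbon only, with equal heavy-atom counts, no hydrogen-bond donors or acceptors and no net charge, so the step appears with all of these counts unchanged. The value of compound 3 is a number and not a limit, so the step can be read in full: the limit of < 1000 nM in this assay, at which 1 of the 3 values shown sits.

This single step does not separate the effect of chlorine in place of methyl from that of the different substitution pattern on the ring. Going by these compounds, how the same place would read with a morpholine or a carboxylic acid on the phenyl ring remains open.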